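Swapping the Aryl Group of a Dopamine Receptor Agonist

The source may hold more compounds than are shown below. What is called first, only, known or untested is meant among the compounds shown, and "the series" means these compounds.

Measured so far:
- compound 1, `Cc1ccc(C(=O)NCN2CCC(c3cccc[n+]3[O-])CC2)cc1C`: 38 nM
- compound 2, `Cc1cccc(NC(=O)CN2CCC(c3ccc(O)cc3)CC2)c1`: 70 nM

In a functional assay on HEK293 cells for agonist activity at D(4) dopamine receptor (Homo sapiens), read by FLIPR (on this read-out lower numbers stand for an effect already at smaller amounts and higher numbers for an effect only at larger amounts of compound), compound 1 gives 38 nM, the lowest of the two numbers, while compound 2 gives 70 nM; the two values lie within the scatter of each other, so neither can be called more potent than the other. Going by the values given here, the two compounds share no single-point difference, so no step between them can be drawn.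

Compound 3, `N#Cc1cccc(C(=O)NCN2CCC(c3cccc[n+]3[O-])CC2)c1`, is not yet measured. It arises from compound 1 by one change, (3-cyanophenyl in place of 3,4-dimethylphenyl on a carbonyl carbon), on a carbonyl carbon whose other neighbour is an amide-type nitrogen. Among the compounds with values here, nothing among the measured compounds shows what this change does in this assay. A small step is expected, at most a modest move toward higher numbers, which may not exceed the scatter; the expected step is a 1.8-fold higher number from compound 1 to compound 3 (0.27 log units; within the scatter). Compound 3 is therefore estimated at 70 nM, in the range 20 nM to 250 nM.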

Compound 3, half-maximal effective concentration: 840 nM
For compound 3 the middle estimate is 12-fold (1.08 log units) below the measured one; measured number above the stated range.
By their numbers in this assay, from the lowest: compounds 1 and 2 (each within the scatter of the next); then compound 3.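

In this assay, the group on this carbonyl carbon turns out to matter: 3-cyanophenyl in place of 3,4-dimethylphenyl gives a 22-fold higher number from compound 1 to compound 3 (1.34 log units; beyond the scatter), a large step. The earlier compounds shown here could not show this, since no single-point step joined them; now one position in the shared core has a measured sensitivity, even though the two groups have the same number of heavy atoms and the same kind of ring. Nothing available explains why the step is this large.

The swap removes both methyl groups and adds a nitrile in one move, so the compounds shown cannot separate the loss of one from the gain of the other. Going by these compounds, whether a plain phenyl, a 3-methylphenyl or a 3-chlorophenyl group at this place would stand nearer compound 1 or compound 3 remains open.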